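A few compounds are considered here, and "the series" means these few. Any claim that something is new, unique, unknown or untested is made for them only; others in the source may bear on it.

Measured compounds:
compound 1 `Cn1c(-c2ccc(NC(=O)CCl)cc2)nc(-c2ccccc2)c1-c1ccccc1`, 53.2%
compound 2 `Cn1c(-c2ccc(NC(=O)CSc3nc4ccccc4o3)cc2)nc(-c2ccccc2)c1-c1ccccc1`, 79.3%
compound 3 `Cn1nnnc1SCC(=O)Nc1ccc(-c2nc(-c3ccccc3)c(-c3ccccc3)n2C)cc1`, 84%

All three were read in a functional assay on HT-29 cells (Homo sapiens) for cytotoxicity, read by MTT assay, with a stated time of 24 h, tested at 32 ug/mL; on this read-out higher numbers stand for a stronger effect at the one concentration tested and lower numbers for a weaker effect. Compound 3 gives the highest number of the three, yet compound 2 sits within the scatter of it, so neither can be called the stronger; only compound 1 is clearly lower, as the step of a number 30.8 percentage points higher from compound 1 to compound 3 (beyond the scatter) shows. The two measured steps that change the chain end both replaced the chloro group with a heteroaryl sulfanyl group, and both raised the read-out: a number 26.1 percentage points higher from compound 1 to compound 2 (beyond the scatter) and a number 30.8 percentage points higher from compound 1 to compound 3 (beyond the scatter). Exchanging one heteroaryl for the other did little: a number 4.7 percentage points higher from compound 2 to compound 3 (within the scatter).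

Compound 4 `CCN1CCN(CC(=O)Nc2ccc(-c3nc(-c4ccccc4)c(-c4ccccc4)n3C)cc2)CC1` is not yet measured. It differs from compound 3 as follows: 4-ethylpiperazin-1-yl in place of (1-methyl-1H-tetrazol-5-yl)sulfanyl on a saturated chain carbon bound to a carbonyl carbon. Among the measured compounds shown here, no measured step removes the sulfanyl link or brings in a saturated amine ring, so none of the three steps bears on this change directly; the data only show that the chloro compound is weaker than either sulfanyl compound. The expected step is therefore uncertain and the estimate sits between the two observed levels: a number 19 percentage points lower from compound 3 to compound 4 (beyond the scatter). Compound 4 is expected to give about 65%, in the range 40% to 88%.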

Compound 4, a percentage reported as activity, at one concentration (the size of the read-out at that concentration, not a potency): 38.8%
The estimate for compound 4 lay 26.2 percentage points above the measured number; the whole stated range lies above it.
By their numbers in this assay, from the lowest: compound 4; then compound 1; then compounds 2 and 3 (each within the scatter of the next).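

At the saturated chain carbon bound to a carbonyl carbon, replacing chloro does not always raise the number in this assay: 4-ethylpiperazin-1-yl in place of chloro gives a number 14.4 percentage points lower from compound 1 to compound 4 (beyond the scatter), so this position can lose as well as gain. The fall is larger against the two sulfanyl compounds, a number 45.2 percentage points lower from compound 3 to compound 4 (beyond the scatter) and a number 40.5 percentage points lower from compound 2 to compound 4 (beyond the scatter), so among these compounds the high numbers go with the heteroaryl sulfanyl groups and not with every ring-bearing group at this place. Nothing measured here accounts for this fall.

The compounds shown leave open whether the sulfur link or the heteroaryl ring carries the higher numbers, which a plain methylsulfanyl group at this place would help to separate. Also open, as far as these compounds go, is how a morpholine ring or a piperazine ring without the ethyl group would read in this assay.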